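Triazene series: chloro in place of nitro

This account rests on a few compounds, and the source may have more. Where it says the series, first, only, none or still open, it means among the compounds named here.

Compound 3 `O=[N+]([O-])c1ccc(/N=N/N2CCCC2)cc1` is a triazene whose aromatic ring carries a nitro group. In an ADME assay on BHK-21 cells (Mesocricetus auratus) for cytotoxicity, read by MTT assay, with a stated time of 96 h (a higher number here means that more compound is tolerated, a lower number that less compound is tolerated), compound 3 gives >= 100000 nM, which is a limit of the assay and not a number. This is recorded as the limit of >= 100000 nM in this assay, at which 1 of the 3 values shown sits. Compound 1 `Clc1ccc(/N=N/N2CCCCC2)cc1` carries chloro and a larger saturated ring on the triazene. In this assay compound 1 gives > 100000 nM, again a limit rather than a number, recorded as the limit of > 100000 nM in this assay, at which 1 of the 3 values shown sits. Compound 2 `Cc1c(/N=N/c2ccccc2)ccc(NC[C@@H]2CCCN3CCCC[C@H]23)c1C` comes from a different part of the series; in this assay compound 2 gives 47000 nM. Compound 3 therefore stands at the top end of what the readings show, with nothing measured above it.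

Compound 4 `Clc1ccc(/N=N/N2CCCC2)cc1` has not yet been measured. The change from compound 3 is chloro in place of nitro on an aromatic carbon. For the measured compounds named here, no measured step in this assay is available to anchor the size. Since compound 1, which also carries chloro, sits at a limit in this assay, the step of a number no higher from compound 3 to compound 4 (the limit leaves the size open) is expected to be none beyond the scatter. Compound 4 is estimated at 100000 nM, within 50000 nM to 200000 nM, and is most likely to be reported only as a limit again.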

Compound 4, half-maximal cytotoxic concentration: > 100000 nM
Compound 4 was reported as a limit (the forecaster's own chance of this, stated with the estimate: 80%); the middle value sits exactly at the limit.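

Compound 3 and compound 4 are both recorded only as limits of the assay in this assay; the step between them cannot be read. The compounds shown leave open whether chloro in place of nitro on an aromatic carbon changes the tolerated concentration at all.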